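Taking the nitro group off compound 3

The source may hold more compounds than are shown below. What is called first, only, known or untested is meant among the compounds shown, and "the series" means these compounds.

In a functional assay on C6 cells (Rattus norvegicus) for inhibition, read by sulforhodamine B assay, with a stated time of 72 h (a lower number here means that less compound is needed, a higher number that more compound is needed for the effect), compound 1 `O=C(/C=C/c1ccc([N+](=O)[O-])o1)c1ccc(I)cc1` gives 2100 nM, compound 2 `O=C(/C=C/c1ccc([N+](=O)[O-])o1)c1ccc(-c2ccccc2)cc1` gives 17700 nM and compound 3 `O=C(/C=C/c1ccc([N+](=O)[O-])o1)c1ccc(C2CCCCC2)cc1` gives 5100 nM. The number for compound 3 is thus the second highest of the three. On one side there is a 2.4-fold higher number from compound 1 to compound 3 (0.39 log units; beyond the scatter), and on the other there is a 3.5-fold lower number from compound 2 to compound 3 (0.54 log units; beyond the scatter).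

Compound 4 `O=C(/C=C/c1ccco1)c1ccc(C2CCCCC2)cc1` keeps the cyclohexyl group and changes something else: hydrogen in place of nitro on an aromatic carbon. This is hydrogen in place of nitro on an aromatic carbon, next to the ring oxygen, so that 5-nitrofuran-2-yl becomes furan-2-yl.

All three measured compounds carry the nitro group, and their steps only exchange iodo, phenyl and cyclohexyl. None of them therefore measures this change directly, and they serve only as a yardstick of size. The largest is an 8.4-fold higher number from compound 1 to compound 2 (0.93 log units; beyond the scatter), and removing a whole group seems unlikely to matter less than that exchange. The direction is a judgement the measurements cannot test, but a higher number seems more likely than a lower one. The expected step is a 4.9-fold higher number from compound 3 to compound 4 (0.69 log units; beyond the scatter). Compound 4 is estimated at 25000 nM, with an expected range from 7000 nM to 90000 nM.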

Compound 4, half-maximal effective concentration: > 50000 nM
Compound 4 was reported as a limit; the forecaster's own chance of this, stated with the estimate: 25%; middle value at least 2.0-fold (0.30 log units) from the limit.
By their numbers in this assay, from the lowest: compound 1; then compound 3; then compound 2. At a limit, above all of these: compound 4.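

On these data alone, compound 4 stands at a limit of the assay rather than at a number, so the true size of its step remains unknown and only its lower bound can be read: the limit of > 50000 nM in this assay, at which 1 of the 4 values shown sits. In this assay, among these compounds, hydrogen in place of nitro next to the ring oxygen gives an at least 9.8-fold higher number from compound 3 to compound 4 (0.99 log units; beyond the scatter), the first direct reading of this position, which no step among the earlier compounds touched. Those compounds exchanged only iodo, phenyl and cyclohexyl, with an 8.4-fold higher number from compound 1 to compound 2 (0.93 log units; beyond the scatter) as their largest step, and the single loss of the nitro group, with the cyclohexyl group kept, counts for a change of at least similar size.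

The compounds shown do not tell how a nitrile, a carboxylic acid or an amine would read in place of the nitro group, and so they leave open whether nitro itself is needed or whether other groups could stand there. Among the compounds shown here, this change is also seen only with cyclohexyl on the other ring, and its size with iodo or phenyl there remains unknown.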